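Series notes: tert-butyl to phenyl, compound 4

The compounds below may be only part of what the source reports. "The series", "measured", "known", "first", "only" and "open" are said of these compounds alone.

Measured values in a functional assay on Jurkat cells for inhibition of nuclear factor NF-kappa-B complex (Homo sapiens); on this read-out higher numbers stand for weaker inhibition and lower numbers for stronger inhibition:
compound 1 `CCOC(=O)c1cnc(C(F)(F)F)nc1NN1C(=O)C=C(C)C1=O`: 1000 nM
compound 2 `CCOC(=O)c1cnc(CC)nc1NN1C(=O)C=C(C)C1=O`: 10000 nM
compound 3 `CCOC(=O)c1cnc(C(C)(C)C)nc1NN1C(=O)C=C(C)C1=O`: 1000 nM

Compound 3 stands level with compound 1; together they give the two lowest numbers of the three, and compound 2 is the furthest away. Two steps define the spread: a 10-fold lower number from compound 2 to compound 3 (1.00 log units; beyond the scatter) and a 10-fold higher number from compound 1 to compound 2 (1.00 log units; beyond the scatter), while no change at the digits printed from compound 1 to compound 3 (within the scatter). So far ethyl is the only group that raises the number; trifluoromethyl and tert-butyl cannot be told apart in this assay.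

Compound 4 `CCOC(=O)c1cnc(-c2ccccc2)nc1NN1C(=O)C=C(C)C1=O` introduces (phenyl in place of tert-butyl on an aromatic carbon). For the measured compounds named here, no measured step swaps in a ring at this carbon, so none bears on it directly. The nearest analogy is the set of three groups already tried at the same carbon, which covers the whole spread seen in this assay: two of them sit at the lower number and one at the higher. Going by the values given here, on that basis the expected result for compound 4 is near compound 3, a 1.5-fold higher number from compound 3 to compound 4 (0.18 log units; within the scatter), but the range must stay wide because the series holds no precedent for an aromatic group here. The estimate for compound 4 is 1500 nM, with a range from 300 nM to 10000 nM.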

Compound 4, half-maximal inhibitory concentration: 100 nM
Beside the measured number, compound 4's estimate is 15-fold (1.18 log units) above it; measured number outside the range, below it.
By their numbers in this assay, from the lowest: compound 4; then compounds 1 and 3 (each within the scatter of the next); then compound 2.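

Working from this assay as the read-out, phenyl on the aromatic carbon between two ring nitrogen atoms gives a 10-fold lower number from compound 3 to compound 4 (1.00 log units; beyond the scatter) and also a 10-fold lower number from compound 1 to compound 4 (1.00 log units; beyond the scatter) so the level shared by trifluoromethyl and tert-butyl is not the lowest this carbon can reach. For the compounds shown here, with a 100-fold lower number from compound 2 to compound 4 (2.00 log units; beyond the scatter) as the widest step, the choice of group at this single carbon now moves the number across a wider span than the three non-ring groups alone showed, and the one group carrying a ring gives the lowest number of the four. Nothing at hand explains why phenyl lowers the number.

The compounds shown leave open whether any ring at this carbon would do, or only an aromatic one: cyclohexyl would separate those two readings, while a pyridyl ring or a phenyl carrying a methoxy group or a chlorine would show how much change the phenyl accepts. Also open, as far as these compounds go, is whether the step to phenyl holds when the ethoxycarbonyl group gives way to a carboxylic acid or a primary amide.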